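A few compounds are considered here, and "the series" means these few. Any claim that something is new, unique, unknown or untested is made for them only; others in the source may bear on it.

In a functional assay on DU-145 cells (Homo sapiens) for inhibition (on this read-out lower numbers stand for stronger inhibition and higher numbers for weaker inhibition), compound 3 `Cc1ccc(Br)cc1-c1cc(Nc2ccc(Cl)cc2)nc(N)n1` gives 100 nM. Compound 2 `Cc1ccc(Cl)cc1-c1cc(Nc2ccc(Br)cc2)nc(N)n1` gives 130 nM, which lies within the scatter of the value for compound 3, so the two form one level in this small set. Compound 1 `Cc1ccc(F)cc1-c1cc(Nc2ccc(Cl)cc2)nc(N)n1` is reported only as a limit, > 1000 nM. Among the measured compounds shown here, the one measured single-site step is an at least 10-fold lower number from compound 1 to compound 3 (1.00 log units; beyond the scatter), with bromo in place of fluoro on an aromatic carbon.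

Compound 4 `Cc1ccc(Br)cc1-c1cc(Nc2ccc(Br)cc2)nc(N)n1` differs from compound 3 by bromo in place of chloro on an aromatic carbon, para to a large group, or 4-chlorophenyl to 4-bromophenyl. The measured step involves a different replacement at a different site, so its size is not carried over to this change. The closer guide is compound 2, which already carries the 4-bromophenyl group and gives 130 nM. For the measured compounds named here, no measured step isolates the chloro-to-bromo exchange at this site. No change beyond the scatter is therefore expected, and the expected step is no change at the digits printed from compound 3 to compound 4 (within the scatter). For compound 4 the estimated value is 100 nM, with an expected range from 45 nM to 230 nM.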

Compound 4, half-maximal inhibitory concentration: 110 nM
Compound 4: middle estimate off by 1.1-fold (0.04 log units), on the low side, within the range that was stated.
By their numbers in this assay, from the lowest: compounds 3, 4 and 2 (each within the scatter of the next). At a limit, above all of these: compound 1.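

In this assay the change from 4-chlorophenyl to 4-bromophenyl now has a measured size, a 1.1-fold higher number from compound 3 to compound 4 (0.04 log units; within the scatter), so this site, para to a large group, takes either halogen with no difference that can be told from the scatter. Among the compounds shown here, the same exchange at the other halogen site of the shared core reads a 1.2-fold lower number from compound 2 to compound 4 (0.07 log units; within the scatter), so with 4-bromophenyl in place, chloro and bromo at that second site also form one level, which the single step from fluoro to bromo could not show. Across compound 2, compound 3 and compound 4 the two heavier halogens are thus interchangeable at both sites in this read-out, and nothing measured here gives a reason for that.

On these data alone, compound 1 remains a limit, > 1000 nM, so the full size of the step from fluoro to bromo stays unknown. Also open, as far as these compounds go, is whether this level holds beyond chloro and bromo, for instance with iodo, methoxy or a nitrile at either site.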